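Swapping the aryl group on a chalcone-type carbonyl

The source may hold more compounds than are shown below. What is called first, only, known or untested is meant among the compounds shown, and "the series" means these compounds.

Among the compounds with values here, compound 1 `COc1ccc(-c2cc3ccccc3nc2/C=C/C(=O)c2ccc(F)cc2)cc1` is tested in a functional assay on NCI-H1299 cells (Homo sapiens) for antiproliferative activity, read by XTT assay, with a stated time of 72 h (a higher number here means a weaker inhibitor, a lower number a stronger inhibitor), where compound 1 gives 820 nM, the highest of the two numbers measured so far. Its nearest neighbour is compound 2 `COc1ccc(-c2cc3ccccc3nc2/C=C/C(=O)c2cccs2)cc1`, and in this assay compound 2 gives 720 nM. Within the data shown here, the one measured step, a 1.1-fold lower number from compound 1 to compound 2 (0.06 log units; within the scatter), exchanges the ring on the carbonyl carbon and leaves the number essentially where it was.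

Compound 3 `COc1ccc(-c2cc3ccccc3nc2/C=C/C(=O)c2ccccn2)cc1` has not yet been measured. Relative to compound 1 it differs as follows: pyridin-2-yl in place of 4-fluorophenyl on a carbonyl carbon. This is the same kind of exchange at the same place as the step between compound 1 and compound 2, which stayed within the scatter, so no step beyond the scatter is expected in this assay in either direction. The expected step is therefore a 1.0-fold lower number from compound 1 to compound 3 (0.01 log units; within the scatter). On that basis compound 3 is estimated at 800 nM, most likely between 350 nM and 1900 nM.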

Compound 3, half-maximal inhibitory concentration: 660 nM
Compound 3: the middle estimate sits 1.2-fold (0.08 log units) above what was measured, and the stated range covers the measured number.
By their numbers in this assay, from the lowest: compounds 3, 2 and 1 (each within the scatter of the next).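

In this assay, a third ring on the carbonyl carbon again leaves the number essentially unchanged, with a 1.2-fold lower number from compound 1 to compound 3 (0.09 log units; within the scatter) and a 1.1-fold lower number from compound 2 to compound 3 (0.04 log units; within the scatter). Both steps lie within the scatter, so 4-fluorophenyl, thiophen-2-yl and pyridin-2-yl cannot be told apart at this position, even though pyridin-2-yl carries a hydrogen-bond acceptor that 4-fluorophenyl lacks. No evidence is available that bears on why this exchange changes so little.

All three groups shown here are aromatic rings, so it remains open whether a cyclohexyl ring, a morpholine or a simple methyl group on the carbonyl carbon would also keep the number in this range. Going by these compounds, it also remains open whether an amine or a carboxylic acid on the pyridin-2-yl ring would produce a step beyond the scatter.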